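Chloro to Fluoro on a Weakly Inhibiting Pair

A few compounds are considered here, and "the series" means these few. Any claim that something is new, unique, unknown or untested is made for them only; others in the source may bear on it.

Compound 1, `COc1cccc(/C=N/NC(=O)c2ccc(C)cc2O)c1`: 20600 nM
Compound 2, `Cc1ccc(C(=O)N/N=C/c2cccc(Cl)c2)c(O)c1`: 24400 nM

In a functional assay (Mus musculus, strain BALB/C) for inhibition, read by MTT assay, with stated times of 24 h and 72 h (on this read-out lower numbers stand for stronger inhibition and higher numbers for weaker inhibition), compound 1 gives 20600 nM and compound 2 gives 24400 nM. Compound 2 carries the larger of the two numbers, but the step of a 1.2-fold higher number from compound 1 to compound 2 (0.07 log units; within the scatter) lies within the scatter, so neither compound can be called the stronger inhibitor; both sit in a weak range.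

Compound 3, `Cc1ccc(C(=O)N/N=C/c2cccc(F)c2)c(O)c1`, has not been measured yet. Its difference from compound 2 is fluoro in place of chloro on an aromatic carbon. Among the measured compounds shown here, the only measured step, from compound 1 to compound 2, also changed the group at this same place and moved the number by a 1.2-fold higher number from compound 1 to compound 2 (0.07 log units; within the scatter), which bears on the new change only loosely, since it swapped a different pair of groups. With no evidence of a shift at this position, the expected step is a 1.0-fold lower number from compound 2 to compound 3 (0.01 log units; within the scatter), that is, none beyond the scatter. Compound 3 is therefore estimated at 24000 nM, with a range from 10000 nM to 60000 nM.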

Compound 3, half-maximal inhibitory concentration: 31200 nM
For compound 3 the middle estimate is 1.3-fold (0.11 log units) below the measured one; measured number inside the range.
By their numbers in this assay, from the lowest: compounds 1, 2 and 3 (each within the scatter of the next).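

Fluoro in place of chloro gives a 1.3-fold higher number from compound 2 to compound 3 (0.11 log units; within the scatter) and fluoro in place of methoxy gives a 1.5-fold higher number from compound 1 to compound 3 (0.18 log units; within the scatter), and both steps lie within the scatter. Where the earlier pair offered a single swap at this place on the aromatic ring, three groups can now be compared, and in this assay all three numbers remain indistinguishable from one another, all in the same weak range. Nothing available here explains why these swaps leave the number within the scatter.

As far as these compounds go, whether an amine, a carboxylic acid or a longer chain at this same place would move the number beyond the scatter remains open. So does the question of whether changes elsewhere on the shared core would matter more than changes here.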